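From 2-methylphenyl to pyridin-3-yl on a shared core

The source may hold more compounds than are shown below. What is called first, only, known or untested is meant among the compounds shown, and "the series" means these compounds.

In a functional assay on HCT-15 cells (Homo sapiens) for cytotoxicity, read by ELISA, with a stated time of 4 days (a lower number here means a stronger inhibitor, a higher number a weaker inhibitor), compound 3 `Cc1ccccc1-c1cc(-c2ccoc2)cc(-c2ccc(Cl)s2)n1` gives 990 nM as its reading, within the usual scatter of compound 1 `Cc1ccsc1-c1cc(-c2ccoc2)cc(-c2ccco2)n1` at 640 nM and clearly lower than compound 2 `Cc1ccsc1-c1cc(-c2ccoc2)cc(-c2ccc(Cl)cc2)n1` with its 2990 nM reading. Compound 4 `Clc1ccc(-c2cc(-c3ccoc3)cc(-c3cccnc3)n2)s1` has pyridin-3-yl in place of 2-methylphenyl on an aromatic carbon and has not yet been measured. Among the compounds with values here, no measured compound carries pyridin-3-yl. Within the data shown here, the one measured step, a 4.7-fold higher number from compound 1 to compound 2 (0.67 log units; beyond the scatter) for 4-chlorophenyl in place of furan-2-yl, is modest and a different exchange, so it bears only loosely here. An estimated 1.2-fold higher number from compound 3 to compound 4 (0.08 log units; within the scatter) is therefore expected in this assay as a shift no larger than the scatter. For compound 4 the expected value is 1200 nM with 350 nM to 4500 nM as its likely range.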

Compound 4, half-maximal inhibitory concentration: 720 nM
For compound 4 the middle estimate is 1.7-fold (0.22 log units) above the measured one, and the stated range covers the measured number.
By their numbers in this assay, from the lowest: compounds 1, 4 and 3 (each within the scatter of the next); then compound 2.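

In this assay, putting pyridin-3-yl in place of 2-methylphenyl gives a 1.4-fold lower number from compound 3 to compound 4 (0.14 log units; within the scatter), a step no larger than the usual scatter. At this place, next to the ring nitrogen, a ring of carbon only and a ring holding one nitrogen and one hydrogen-bond acceptor therefore cannot be told apart on this reading, at least with the 5-chlorothiophen-2-yl and furan-3-yl groups kept the same. No supporting measurement bears on this result. On these data alone, whether a group of a different kind here, such as an amine or a carboxylic acid, would also leave the reading within the scatter remains open.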